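This account rests on a few compounds, and the source may have more. Where it says the series, first, only, none or still open, it means among the compounds named here.

Measured so far:
- compound 1, `CC(C)OC(=O)N1CCC(Oc2ncnc3c2CCN3c2ccc(-c3nccs3)cc2F)CC1`: 79.4 nM
- compound 2, `CCCOC(=O)N1CCC(Oc2ncnc3c2CCN3c2ccc(S(C)(=O)=O)cc2F)CC1`: 79.4 nM

Both values come from a functional assay on CHO-K1 cells for agonist activity at Glucose-dependent insulinotropic receptor (Homo sapiens), read by a luciferase reporter, with a stated time of 5 h; on this read-out higher numbers stand for an effect only at larger amounts of compound and lower numbers for an effect already at smaller amounts. Compound 2 stands level with compound 1 at the digits shown, so the pair shows no difference beyond the usual scatter; nothing in these two numbers separates the thiazolyl-bearing compound 1 from the methylsulfonyl-bearing compound 2.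

The next compound, compound 3, `CN(C)S(=O)(=O)N1CCC(Oc2ncnc3c2CCN3c2ccc(S(C)(=O)=O)cc2F)CC1`, keeps everything of compound 2 except the cap on the ring nitrogen: dimethylsulfamoyl in place of propoxycarbonyl on an amine nitrogen in a ring.

For the measured compounds named here, no pair of measured compounds here differs in only this place, so there is no measured step to lean on. With the group counts equal and the acceptor count unchanged, the expectation for the step of a 1.4-fold higher number from compound 2 to compound 3 (0.14 log units; within the scatter) is a small shift, if any, towards an effect at somewhat larger amounts, not clearly beyond the scatter. Compound 3 is therefore expected to give about 110 nM in this assay. For compound 3 the expected range runs from 35 nM to 400 nM.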

Compound 3, half-maximal effective concentration: 398 nM
For compound 3 the middle estimate is 3.6-fold (0.56 log units) below the measured one; measured number inside the range.
By their numbers in this assay, from the lowest: compounds 1 and 2 (each within the scatter of the next); then compound 3.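

For the compounds shown here, the cap on the amine nitrogen in a ring is the first place where a single change can be read from this assay and the reading is a 5.0-fold higher number from compound 2 to compound 3 (0.70 log units; beyond the scatter) on going to dimethylsulfamoyl in place of propoxycarbonyl. The position therefore does not treat these two caps alike, even though the two match in heavy atoms and in hydrogen-bond acceptors, so those counts alone do not set the number here. Nothing measured on these compounds accounts for the step.

Still open, from the compounds shown here alone, is whether the loss follows the sulfamoyl unit itself or the departure of the propoxycarbonyl group, which an acetyl cap or a plain methanesulfonyl cap on the same nitrogen would help to separate. Also open, going by these compounds, is whether a longer chain such as butoxycarbonyl carries the number in either direction.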